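Replacing the fluorophenyl group of compound 3

A few compounds are considered here, and "the series" means these few. Any claim that something is new, unique, unknown or untested is made for them only; others in the source may bear on it.

Among the compounds with values here, in a functional assay on HEK293 cells with D(4) dopamine receptor (Homo sapiens) as the target, read by FLIPR (on this read-out higher numbers stand for an effect only at larger amounts of compound and lower numbers for an effect already at smaller amounts), compound 3 `O/N=C(\CCN1CCN(c2ccccn2)CC1)c1ccc(F)cc1` gives 31 nM, the highest of the three numbers measured so far. Compound 1 `O/N=C(\CCN1CCN(c2ccccn2)CC1)c1ccccc1Cl` gives 24 nM, and compound 2 `O/N=C(\CCN1CCN(c2ccccn2)CC1)c1cccc(Cl)c1` gives 11.9 nM. Compound 4 `Cc1ccc(O)c(/C(CCN2CCN(c3ccccn3)CC2)=N/O)c1` differs from compound 3 by 2-hydroxy-5-methylphenyl in place of 4-fluorophenyl on a carbon with a double bond to nitrogen. The earlier steps shown here each exchanged one aryl ring for another and stayed small: a 2.0-fold lower number from compound 1 to compound 2 (0.30 log units; within the scatter), a 1.3-fold higher number from compound 1 to compound 3 (0.11 log units; within the scatter) and a 2.6-fold higher number from compound 2 to compound 3 (0.42 log units; beyond the scatter). Within the data shown here, the incoming group carries a hydrogen-bond donor and acceptor that no measured compound has, so no direction can be read from the data; only a modest shift in this assay is expected. Compound 4 is therefore estimated at 30 nM in this assay, within 8 nM to 120 nM, which corresponds to the expected step of a 1.0-fold lower number from compound 3 to compound 4 (0.01 log units; within the scatter).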

Compound 4, half-maximal effective concentration: 19.2 nM
The estimate for compound 4 lay 1.6-fold (0.19 log units) above the measured number, and the stated range covers the measured number.
By their numbers in this assay, from the lowest: compounds 2, 4, 1 and 3 (each within the scatter of the next, the first and the last beyond it).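

In this assay, a ring with a hydrogen-bond donor and acceptor, which none of the earlier rings has, is tolerated on the carbon with a double bond to nitrogen. The number stays within the scatter of all three earlier compounds (a 1.6-fold lower number from compound 3 to compound 4 (0.21 log units; within the scatter)), (a 1.6-fold higher number from compound 2 to compound 4 (0.21 log units; within the scatter)) and (a 1.3-fold lower number from compound 1 to compound 4 (0.10 log units; within the scatter)). No measurement shown here explains this result.

As far as these compounds go, the new group brings hydroxy and methyl together, so their separate contributions remain unknown. From the compounds shown here alone, it is also open whether an amine or a carboxylic acid on this ring would shift the number further.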